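A few compounds are considered here, and "the series" means these few. Any claim that something is new, unique, unknown or untested is made for them only; others in the source may bear on it.

Compound 1 `ClCc1ccccc1Cn1cnc2c(Cl)nc(Cl)nc21` and compound 2 `ClCc1ccccc1Cn1cnc2c(Cl)ncnc21` share a core; in a functional assay on Hs-578T cells (Homo sapiens) for cytotoxicity, read by sulforhodamine B assay, with a stated time of 48 h (a higher number here means a weaker inhibitor of growth, a lower number a stronger inhibitor of growth), compound 1 gives 3540 nM and compound 2 gives 6600 nM. Going by the values given here, the only change between them is chloro in place of hydrogen on an aromatic carbon, and it made a 1.9-fold lower number from compound 2 to compound 1 (0.27 log units; within the scatter). Compound 3 `ClCc1cccc(Cn2cnc3ncnc(Cl)c32)c1` carries a core of the same atoms joined differently; the difference between the two cores is not broken down here. In this assay compound 3 gives 42700 nM, the highest number of the three. Compound 4 `ClCc1cccc(Cn2cnc3nc(Cl)nc(Cl)c32)c1` is not yet measured; it differs from compound 3 by chloro in place of hydrogen on an aromatic carbon, the same change that led from compound 2 to compound 1. Because that step gave a 1.9-fold lower number from compound 2 to compound 1 (0.27 log units; within the scatter), the step from compound 3 to compound 4 is expected to be about a 1.9-fold lower number from compound 3 to compound 4 (0.29 log units; within the scatter). Compound 4 is therefore estimated at 22000 nM, likely between 10000 nM and 50000 nM.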

Compound 4, concentration for total growth inhibition: 2810 nM
Beside the measured number, compound 4's estimate is 7.8-fold (0.89 log units) above it; the measured number lies below the stated range.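

In this assay the step of a 15-fold lower number from compound 3 to compound 4 (1.18 log units; beyond the scatter) is large, with chloro in place of hydrogen on an aromatic carbon between two ring nitrogen atoms. The same change therefore does not carry over at the same size from one core to the other: the same change on two cores in this assay, a 1.9-fold lower number (0.27 log units; within the scatter) from compound 2 to compound 1 and a 15-fold lower number (1.18 log units; beyond the scatter) from compound 3 to compound 4, 8.2-fold (0.91 log units) apart, beyond the scatter of two such steps. This shows that, for these two pairs, the size of the step cannot simply be copied across cores, but two pairs cannot show why the steps differ or what the change would do on a further core.

The compounds shown leave open whether another group in that place, such as an amine or a methoxy group, would also give steps that differ between the two cores.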